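The compounds below may be only part of what the source reports. "The series", "measured", "known", "first", "only" and "open" are said of these compounds alone.

In a functional assay on HT-29 cells (Homo sapiens) for antiproliferative activity, read by MTT assay, with a stated time of 48 h (a higher number here means a weaker inhibitor, a lower number a stronger inhibitor), three compounds that share a large ring-built core have been measured. Compound 1 `Oc1cc2c(cc1O)Oc1c(O)cccc1CCc1ccc(cc1)Oc1cc(ccc1O)CC2` gives 7510 nM, compound 2 `COc1cccc2c1Oc1cc(O)c(O)cc1CCc1ccc(O)c(c1)Oc1ccc(cc1)CC2` gives 1980 nM, and compound 3 `Oc1ccc2cc1Oc1ccc(cc1)CCc1ccc(O)c(c1)Oc1cccc(c1)CC2` gives 7980 nM. Compound 3 therefore stands level with compound 1, within the usual scatter of repeat measurements, while compound 2 shows a clearly lower number than either.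

The unmeasured compound 4 `Oc1ccc2cc1Oc1cccc(c1)CCc1ccc(O)c(c1)Oc1ccc(cc1O)CC2` differs from compound 3 as follows: hydroxy in place of hydrogen on an aromatic carbon. In short, it carries hydroxy in place of hydrogen on an aromatic carbon. Among the measured compounds shown here, the only measured step between compounds differing in one place is a 3.8-fold lower number from compound 1 to compound 2 (0.58 log units; beyond the scatter), a modest step. Its change is methyl in place of hydrogen on an oxygen on an aromatic ring, which is a different edit. It therefore gives only a rough idea of size and no direction for adding a hydroxy. No step beyond the scatter is expected in this assay, and the expected result is a 1.2-fold lower number from compound 3 to compound 4 (0.09 log units; within the scatter). For compound 4 the estimated value is 6500 nM, with an expected range from 2500 nM to 15000 nM.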

Compound 4, half-maximal inhibitory concentration: 12400 nM
Estimate against measurement, compound 4: 1.9-fold (0.28 log units) below; measured number inside the range.
By their numbers in this assay, from the lowest: compound 2; then compounds 1, 3 and 4 (each within the scatter of the next).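

In this assay, hydroxy in place of hydrogen on an aromatic carbon of a six-membered aromatic ring of carbon only gives a 1.6-fold higher number from compound 3 to compound 4 (0.19 log units; within the scatter) and so adds no effect that can be told apart from repeat-measurement noise. Among the compounds shown here, this is the first reading of a hydroxy added to the shared core, and the only earlier one-place step, a 3.8-fold lower number from compound 1 to compound 2 (0.58 log units; beyond the scatter) for methyl in place of hydrogen on an oxygen on an aromatic ring, lay beyond the scatter and concerned a different edit. Nothing available here bears on why this position tolerates the added hydroxy.

On these data alone, whether an amine or a carboxylic acid on this same aromatic carbon would shift the number beyond the scatter remains open. So does whether a hydroxy added on another aromatic carbon of the core would behave as it does here.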